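A few compounds are considered here, and "the series" means these few. Any claim that something is new, unique, unknown or untested is made for them only; others in the source may bear on it.

The study gathers a small set of compounds built on a shared core and tested in a toxicity assay on HepG2 cells (Homo sapiens) for inhibition, read by CellTiter-Glo, with a stated time of 48 h; a lower number here means a stronger inhibitor, a higher number a weaker inhibitor. For the measured compounds named here, compound 1, `COc1ccc2nc(C)cc(OC(C)C(=O)Nc3cc(C)cc(C)c3)c2c1`, is the only member with a numerical result: in this assay compound 1 gives 39800 nM. Compound 2, `COc1ccc2nc(C)cc(OCC(=O)Nc3cc(C)ccc3OC)c2c1`, stands differently. In this assay compound 2 reaches only > 100000 nM, which is a limit of the assay rather than a measured number. This is the limit of > 100000 nM in this assay, at which 1 of the 2 values shown sits, so compound 2 is known only as lying at the weak edge of what this assay can resolve. Going by the values given here, no step between compound 1 and compound 2 is given, and the two values can only be set side by side.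

Compound 3, `COc1ccc2nc(C)cc(OCC(=O)NNC(=O)c3ccncc3)c2c1`, remains to be measured. It differs from compound 2 in one place: ((pyridin-4-yl)carbonyl)amino in place of 2-methoxy-5-methylphenyl on an amide-type nitrogen. Because compound 2 already sits at the limit of > 100000 nM in this assay, at which 1 of the 2 values shown sits, no step beyond the usual scatter is expected in this assay. The estimate for compound 3 therefore means a step of an at least 1.1-fold lower number from compound 2 to compound 3 (0.04 log units; that floor lies within the scatter). Compound 3 is expected to give about 90000 nM in this assay, within a range from 25000 nM to 300000 nM, with a real chance that again only a limit is reported.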

Compound 3, half-maximal inhibitory concentration: > 100000 nM
Compound 3: no number, only a limit (the forecaster's own chance of this, stated with the estimate: 60%); at least 1.1-fold (0.04 log units) between middle value and limit.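

In this assay compound 3 gives > 100000 nM as a limit of the assay, not a number. With compound 2 at a limit as well, no step can be read from compound 2 to compound 3: the limit of > 100000 nM in this assay, at which 2 of the 3 values shown sit. The compounds shown leave open whether ((pyridin-4-yl)carbonyl)amino in place of 2-methoxy-5-methylphenyl on an amide-type nitrogen changes the inhibition at all.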